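The source may hold more compounds than are shown below. What is called first, only, known or untested is meant among the compounds shown, and "the series" means these compounds.

Compound 1, `CC[C@@H]1O[C@H](COCc2ccccc2)[C@@H](OCc2ccccc2)[C@H](OCc2ccccc2)[C@H]1O`, is the starting point. In a functional assay on HeLa cells (Homo sapiens) for antiproliferative activity, read by sulforhodamine B assay (on this read-out higher numbers stand for weaker inhibition of growth and lower numbers for stronger inhibition of growth), compound 1 gives 19800 nM. Compound 2, `CC[C@@H]1O[C@H](COCc2ccccc2)[C@@H](OCc2ccccc2)[C@H](OCc2ccccc2)[C@H]1OC(C)=O`, differs from it in one place: acetyl in place of hydrogen on an oxygen on a saturated carbon. In this assay compound 2 reaches only a limit of the measurement, > 50000 nM. The step is therefore an at least 2.5-fold higher number from compound 1 to compound 2 (0.40 log units; beyond the scatter), and its size is known only as a lower bound because the limit of > 50000 nM in this assay, at which 1 of the 3 values shown sits, applies.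

Compound 3, `CC(C)C[C@H]1O[C@H](COCc2ccccc2)[C@@H](OCc2ccccc2)[C@H](OCc2ccccc2)[C@H]1O`, rests on a different core; how its core differs from that of compound 1 is not broken down here. In this assay compound 3 gives 43900 nM, a higher number than compound 1, and the gap between the two lies beyond the usual scatter.

Compound 4, `CC(=O)O[C@@H]1[C@@H](OCc2ccccc2)[C@H](OCc2ccccc2)[C@@H](COCc2ccccc2)O[C@@H]1CC(C)C`, stands to compound 3 as compound 2 stands to compound 1: acetyl in place of hydrogen on an oxygen on a saturated carbon. The place of the change reads the same in both pairs, so this is the same change made on a second core. Whether a change that weakened growth inhibition on the core of compound 1 does so again on the core of compound 3 is what compound 4 will show. Resting on the step of an at least 2.5-fold higher number from compound 1 to compound 2 (0.40 log units; beyond the scatter), compound 4 is expected to show a 2.5-fold higher number from compound 3 to compound 4 (0.40 log units; beyond the scatter). Since compound 3 already gives 43900 nM, compound 4 is estimated at 110000 nM, between 40000 nM and 300000 nM.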

Compound 4, concentration for 50% growth inhibition: > 50000 nM
Compound 4: no number, only a limit; the forecaster's own chance of this, stated with the estimate: 70%; the middle value is on the limit's open side.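

In this assay compound 4 reaches only a limit of the measurement, > 50000 nM. The step on this second core is therefore an at least 1.1-fold higher number from compound 3 to compound 4 (0.05 log units; that floor lies within the scatter), which means that it fits with the weaker growth inhibition seen on the core of compound 1 but does not show on its own that the acetyl weakened growth inhibition here, since the smallest step it allows could be ordinary scatter. Carrying the change across the two cores thus meets nothing that contradicts it, yet neither a confirmed repeat nor a matching size can be claimed: the same change on two cores in this assay, an at least 2.5-fold higher number (0.40 log units; beyond the scatter) from compound 1 to compound 2 and an at least 1.1-fold higher number (0.05 log units; that floor lies within the scatter) from compound 3 to compound 4; the limit leaves it open whether they differ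

On these data alone, all four compounds carry either hydrogen or acetyl on this oxygen, so it remains open what another group in that place, such as an amine or an ester with a longer chain, would do to growth inhibition. Also open, as far as these compounds go, is how large the step truly is on either core, as that would take a number rather than a limit for compound 2 and compound 4.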